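The source may hold more compounds than are shown below. What is called first, only, known or untested is meant among the compounds shown, and "the series" means these compounds.

Two compounds share one core and differ only in the group on the amine nitrogen of the six-membered non-aromatic ring. In a functional assay on isolated protein for inhibition of Glucose-dependent insulinotropic receptor (Rattus norvegicus), read by HTRF and cAMP accumulation (a lower number here means a smaller maximal response, a higher number a larger maximal response), compound 1 `Cc1nc(S(C)(=O)=O)ccc1Oc1ncnc(OC2CCN(C(=O)SC(C)C)CC2)c1F` gives 81%, while compound 2 `Cc1nc(S(C)(=O)=O)ccc1Oc1ncnc(OC2CCN(C(=S)OC3(C)CC3)CC2)c1F` gives 49%. Among the compounds with values here, the single measured step is a number 32 percentage points lower from compound 1 to compound 2 (beyond the scatter). Within the data shown here, compound 2 therefore stands lowest of the two numbers, with compound 1 as its only neighbour and a number beyond the scatter above it.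

Compound 3 `Cc1nc(S(C)(=O)=O)ccc1Oc1ncnc(OC2CCN(C(=O)c3ncc(Cl)cn3)CC2)c1F` takes the same place for its change: a group of 9 heavy atoms (5 carbon, 2 nitrogen, 1 oxygen, 1 chlorine; one six-membered aromatic ring with 2 hetero atoms) in place of a group of 7 heavy atoms (5 carbon, 1 oxygen, 1 sulfur; one three-membered non-aromatic ring of carbon only), on an amine nitrogen in a ring. Among the measured compounds shown here, only the step from compound 1 to compound 2 bears on it, since both changes replace the group on that amine nitrogen, and that step was large. It shows that this position can move the maximal response strongly, but it gives no direction for a group of the kind that enters in compound 3. Some recovery toward the number of compound 1 is expected, so the step of a number 16 percentage points higher from compound 2 to compound 3 (beyond the scatter) is estimated as moderate and upward, though close to the scatter. For compound 3 the expected value in this assay is 65%, within a range from 40% to 90%.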

Compound 3, largest response reached (reported as efficacy), in percent of the reference or control that the assay uses: 77%
The estimate for compound 3 lay 12 percentage points below the measured number, and the stated range covers the measured number.
By their numbers in this assay, from the lowest: compound 2; then compounds 3 and 1 (each within the scatter of the next).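

In this assay, the step to the 5-chloropyrimidin-2-yl carbonyl group is a number 28 percentage points higher from compound 2 to compound 3 (beyond the scatter), which shows that a group with a six-membered aromatic ring on this amine nitrogen can carry a high maximal response and that the low number of compound 2 does not hold for every group with a ring at this place. Within the data shown here, replacing isopropylsulfanyl with 5-chloropyrimidin-2-yl on the carbonyl carbon gives a number 4 percentage points lower from compound 1 to compound 3 (within the scatter), so these two quite different groups on that carbon cannot be told apart in this read-out, and among the three compounds only compound 2, the one without a carbonyl group on this nitrogen, stands apart. No measurement shown here accounts for the difference between these groups.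

The compounds shown leave open whether the low number of compound 2 follows from its sulfur-bearing linking atom or from its 1-methylcyclopropyl part, as the two change together in the steps to compound 1 and compound 3. They also leave open how the maximal response would move with an amine on the carbonyl carbon, or with a phenyl ring or a pyrimidine ring without its chlorine in place of 5-chloropyrimidin-2-yl.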